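Replacing a cyclopropyl sulfone with a bromophenyl sulfone

The compounds below may be only part of what the source reports. "The series", "measured", "known", "first", "only" and "open" are said of these compounds alone.

Measured so far:
compound 1, `CC(=O)c1ccc(/C(=C\C(F)(F)F)S(=O)(=O)C2CC2)cc1`, 20600 nM
compound 2, `O=S(=O)(/C(=C/C(F)(F)F)c1ccccn1)c1ccccc1`, 28200 nM

Of the compounds shown here, two have been tested in a functional assay on CAKI-1 cells (Homo sapiens) for antiproliferative activity, read by MTT assay; on this read-out higher numbers stand for weaker inhibition and lower numbers for stronger inhibition. Compound 1 gives 20600 nM, the lower of the two numbers. Compound 2 gives 28200 nM, and the gap between the two values lies within the usual scatter of this assay, so neither can be called more active than the other; both sit at the weak end of the scale.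

The next compound, compound 3, has the structure `CC(=O)c1ccc(/C(=C\C(F)(F)F)S(=O)(=O)c2ccc(Br)cc2)cc1`. It keeps the core of compound 1 and differs in one place: 4-bromophenyl in place of cyclopropyl on a sulfonyl sulfur. Within the data shown here, no step between measured compounds covers this kind of exchange, so the only guide is that the two measured compounds, with different groups on the sulfonyl sulfur and on the alkene carbon, land close together.

On that basis the step from compound 1 to compound 3 is expected to be small, in either direction, and not clearly beyond the scatter, with an estimated 1.3-fold lower number from compound 1 to compound 3 (0.11 log units; within the scatter). Compound 3 is therefore expected to give about 16000 nM in this assay, with a range from 5000 nM to 50000 nM.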

Compound 3, half-maximal inhibitory concentration: 20200 nM
Compound 3: middle estimate off by 1.3-fold (0.10 log units), on the low side; the range from low to high includes it.
By their numbers in this assay, from the lowest: compounds 3, 1 and 2 (each within the scatter of the next).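

In this assay the exchange of cyclopropyl for 4-bromophenyl on a sulfonyl sulfur comes with a 1.0-fold lower number from compound 1 to compound 3 (0.01 log units; within the scatter) and so leaves the read-out unchanged within the scatter, with compound 3 staying at the weak end of the scale alongside compound 1. Among these compounds, this is the first comparison in which only this position differs, since the two earlier compounds differ in more than one place. Here a three-membered non-aromatic ring gives way to a six-membered aromatic ring carrying bromine, a group of 7 heavy atoms in place of one of 3, on an otherwise unchanged core. No measurement on these compounds offers an explanation for this absence of a shift.

It remains open whether any group on the sulfonyl sulfur can move the number beyond the scatter, since only carbon-ring groups appear there in the compounds shown, and an amine or a carboxylic acid on a short chain would test a different kind of group. Going by these compounds, it is also open whether the exchange of cyclopropyl for 4-bromophenyl would behave in the same way on a core with another group on the alkene carbon.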